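The source may hold more compounds than are shown below. What is called first, only, known or untested is meant among the compounds shown, and "the series" means these compounds.

Compound 1 `Cc1nc(-c2cccnc2)sc1-c1nnc(-c2ccncc2)o1`: in an ADME assay on HeLa cells (Homo sapiens) for cytotoxicity, read by MTT assay (on this read-out lower numbers stand for higher toxicity in this test and higher numbers for lower toxicity in this test), compound 1 gives > 100 ug/mL, which is a limit of the test and not a number.
Compound 2 `Cc1nc(-c2cccnc2)sc1-c1nnc(-c2cccnc2)o1`: compound 2 gives > 100 ug/mL, again a limit.
Compound 3 `Cc1nc(-c2cccnc2)sc1-c1nnc(-c2cccc(Cl)c2Cl)o1`: compound 3 gives > 100 ug/mL, also a limit.

Compound 2 therefore stands at the upper edge of what this assay can report, together with the two other measured compounds, as the limit of > 100 ug/mL in this assay, at which 3 of the 3 values shown sit, shows. The steps from compound 1 to compound 2 a step that the two limits leave unreadable from compound 1 to compound 2, from compound 1 to compound 3 a step that the two limits leave unreadable from compound 1 to compound 3 and from compound 2 to compound 3 a step that the two limits leave unreadable from compound 2 to compound 3 are all left unreadable by those limits.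

Compound 4 `Cc1nc(-c2cccnc2)sc1-c1nnc(-c2ccc(Cl)cc2)o1` differs from compound 2 by 4-chlorophenyl in place of pyridin-3-yl on an aromatic carbon. Going by the values given here, the steps that bear on this change, the exchange of a pyridinyl group for a chlorinated phenyl ring in the steps to compound 3, gave no readable size, so no step beyond the scatter is expected in this assay; compound 4 is expected to sit at the limit as well.

Compound 4 is estimated at 120 ug/mL, between 60 ug/mL and 250 ug/mL, which is expected to mean a step that the limit leaves unreadable from compound 2 to compound 4.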

Compound 4, half-maximal cytotoxic concentration: > 100 ug/mL
Compound 4 was reported as a limit; the forecaster's own chance of this, stated with the estimate: 80%; the middle value does not contradict the limit.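

The steps linking compound 4 with compound 1, compound 2 and compound 3 cannot be read in this assay, because all four compounds sit at the same limit: the limit of > 100 ug/mL in this assay, at which 4 of the 4 values shown sit.

The compounds shown leave open whether the groups on the shared core differ in cytotoxicity at all, and how they would rank.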